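This account rests on a few compounds, and the source may have more. Where it says the series, first, only, none or still open, it means among the compounds named here.

Compound 2 `O=C(Nc1cccc(F)c1)N[C@H]1CC[C@H](Oc2ccc(F)cc2)CC1` is the starting point, and in a functional assay on CRL2813 cells (Homo sapiens) for cytotoxicity, read by sulforhodamine B assay, with a stated time of 5 days (a higher number here means a weaker inhibitor, a lower number a stronger inhibitor), compound 2 gives 8300 nM. Of the two numbers recorded, compound 2 stands highest; its nearest neighbour is compound 3 `O=C(Nc1cccc(Cl)c1)N[C@H]1CC[C@H](Oc2ccc(F)cc2)CC1`, which gives 5900 nM, and the two sit within the scatter of each other. Compound 1 `Cc1ccc(NC(=O)N[C@H]2CC[C@H](Oc3ccc(F)cc3)CC2)cc1` reaches only the limit of this assay at > 20000 nM. The change followed here, (2-methoxyphenyl in place of 3-fluorophenyl on an amide-type nitrogen), leads to compound 4 `COc1ccccc1NC(=O)N[C@H]1CC[C@H](Oc2ccc(F)cc2)CC1`. The measured steps that bear on it are the aryl exchanges an at least 2.4-fold lower number from compound 1 to compound 2 (0.38 log units; beyond the scatter) and an at least 3.3-fold lower number from compound 1 to compound 3 (0.53 log units; beyond the scatter), both at least modest, and the halogen swap a 1.4-fold lower number from compound 2 to compound 3 (0.15 log units; within the scatter), which lies within the scatter. Among the compounds with values here, no measured step involves a 2-methoxyphenyl, so the direction stays open. Compound 4 is expected to give about 12000 nM, between 4000 nM and 30000 nM, which would be a 1.4-fold higher number from compound 2 to compound 4 (0.16 log units; within the scatter).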

Compound 4, half-maximal inhibitory concentration: > 20000 nM
Compound 4 ended at the assay's limit; the forecaster's own chance of this, stated with the estimate: 35%; middle value at least 1.6-fold (0.22 log units) from the limit.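

In this assay, the 2-methoxyphenyl exchange gives an at least 2.4-fold higher number from compound 2 to compound 4 (0.38 log units; beyond the scatter) and an at least 3.3-fold higher number from compound 3 to compound 4 (0.53 log units; beyond the scatter), so the group on this amide-type nitrogen can cost the measurable activity seen with 3-fluorophenyl and 3-chlorophenyl. The result for compound 4 is a limit and not a number, and compound 1 also stands at a limit, so the step from compound 1 to compound 4 cannot be read: the limit of > 20000 nM in this assay, at which 2 of the 4 values shown sit.

From the compounds shown here alone, how far past the limit compound 4 lies remains open. So does whether a phenyl ring carrying an amine or a carboxylic acid on this nitrogen would give a readable value.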